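Swapping Methyl for Nitro on the Sulfonyl Ring

The source may report more compounds than this note shows. Statements on the series, on what has been measured and on what is new or still open speak of the compounds shown alone.

Compound 1 `Cc1ccc(S(=O)(=O)N2C/C(=C\c3ccncc3)C(=O)/C(=C/c3ccccc3F)C2)cc1`: > 20000 nM
Compound 2 `O=C1/C(=C/c2ccncc2)CN(S(=O)(=O)c2ccc([N+](=O)[O-])cc2)C/C1=C\c1ccccc1F`: 8800 nM
Compound 3 `Cc1ccc(S(=O)(=O)N2C/C(=C\c3cccnc3)C(=O)/C(=C/c3ccccc3C(F)(F)F)C2)cc1`: 6170 nM

These three compounds were tested in a functional assay on QGY-7703 cells (Homo sapiens) for cytotoxicity, read by MTT assay, with a stated time of 24 h; on this read-out higher numbers stand for weaker inhibition and lower numbers for stronger inhibition. The result for compound 1 is a limit of the assay rather than a number (the limit of > 20000 nM in this assay, at which 1 of the 3 values shown sits). Compound 2 differs from compound 1 by nitro in place of methyl on an aromatic carbon, and this gave an at least 2.2-fold lower number from compound 1 to compound 2 (0.35 log units; beyond the scatter). Compound 2 and compound 3 lie within the scatter of each other. The difference between the core of compound 1 and the core of compound 3 is not broken down here.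

Compound 4 `O=C1/C(=C/c2cccnc2)CN(S(=O)(=O)c2ccc([N+](=O)[O-])cc2)C/C1=C\c1ccccc1C(F)(F)F` has not yet been measured. It differs from compound 3 by nitro in place of methyl on an aromatic carbon, the same change as from compound 1 to compound 2 at the same place. A step of similar size is expected because the earlier change gave an at least 2.2-fold lower number from compound 1 to compound 2 (0.35 log units; beyond the scatter). For compound 4 the expected result in this assay is 2800 nM, likely between 1200 nM and 6500 nM, which would be an expected step of a 2.2-fold lower number from compound 3 to compound 4 (0.34 log units; beyond the scatter).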

Compound 4, half-maximal inhibitory concentration: 7660 nM
The estimate for compound 4 lay 2.7-fold (0.44 log units) below the measured number, outside the stated range (above it).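

On the core of compound 3, nitro in place of methyl gave a 1.2-fold higher number from compound 3 to compound 4 (0.09 log units; within the scatter), so the swap made no clear difference there. In this assay, the change therefore does not carry over as a fixed step from one core to the other: the same change on two cores in this assay, an at least 2.2-fold lower number (0.35 log units; beyond the scatter) from compound 1 to compound 2 and a 1.2-fold higher number (0.09 log units; within the scatter) from compound 3 to compound 4, at least 2.8-fold (0.45 log units) apart, beyond the scatter of two such steps

Going by these compounds, compound 1 stands at > 20000 nM, which is a limit of the assay and not a number, so the true size of the earlier step is unknown, and two cores show neither how the change behaves on others nor which part of the cores sets the difference.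

On these data alone, it remains open whether an amine or a carboxylic acid at the same place would move the number on either core.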